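The source may report more compounds than this note shows. Statements on the series, on what has been measured and on what is new or still open speak of the compounds shown alone.

Three related compounds of a shared core have been measured in an ADME assay on HepG2 cells (Homo sapiens) for cytotoxicity, read by luminescence, CellTiter-Glo and ATP content, with a stated time of 72 h; a lower number here means that less compound is needed, a higher number that more compound is needed for the effect. Compound 1 `COc1ccc(Oc2ccc3c(NCCCNCc4cccc(OC)c4O)ccnc3c2)cc1`, which carries a 4-methoxyphenoxy group, gives 5500 nM. Compound 2 `COc1cccc(CNCCCNc2ccnc3cc(-c4ccc(C(F)(F)F)cc4)ccc23)c1O`, with a 4-(trifluoromethyl)phenyl group in that place, gives 2210 nM, and compound 3 `COc1cccc(CNCCCNc2ccnc3cc(Cc4ccc(C#N)cc4)ccc23)c1O`, with a 4-cyanobenzyl group there, gives 7150 nM. Compound 3 thus has the highest number of the three; its gap to compound 1 is within the scatter, while the step of a 3.2-fold higher number from compound 2 to compound 3 (0.51 log units; beyond the scatter) is beyond it.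

The next compound, compound 4 `COc1cccc(CNCCCNc2ccnc3cc(-c4cccc5ccccc45)ccc23)c1O`, differs from compound 3 in one place: naphthalen-1-yl in place of 4-cyanobenzyl on an aromatic carbon. The two steps that bear on this change are a 3.2-fold higher number from compound 2 to compound 3 (0.51 log units; beyond the scatter) and a 2.5-fold lower number from compound 1 to compound 2 (0.40 log units; beyond the scatter). Both show that the directly attached aryl group of compound 2 goes with a lower number than either the ether of compound 1 or the benzyl of compound 3. Since compound 4 returns to a directly attached aryl group, a modest drop in number is expected, roughly a 2.9-fold lower number from compound 3 to compound 4 (0.46 log units; beyond the scatter), because the step of a 3.2-fold higher number from compound 2 to compound 3 (0.51 log units; beyond the scatter) ran the other way when the directly attached aryl was replaced by a benzyl. Compound 4 is therefore estimated at 2500 nM, with a likely range from 1000 nM to 6500 nM.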

Compound 4, half-maximal effective concentration: 2520 nM
The estimate for compound 4 lay 1.0-fold (0.00 log units) below the measured number; the range from low to high includes it.
By their numbers in this assay, from the lowest: compounds 2 and 4 (each within the scatter of the next); then compounds 1 and 3 (each within the scatter of the next).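

In this assay, the change to naphthalen-1-yl gives a 2.8-fold lower number from compound 3 to compound 4 (0.45 log units; beyond the scatter) and, set against the ether-linked group, a 2.2-fold lower number from compound 1 to compound 4 (0.34 log units; beyond the scatter) at this aromatic carbon of the shared core. The lower numbers at this position are therefore no longer a single case: compound 2 and compound 4 both carry an aromatic ring attached directly to the core, and both lie clearly below compound 1 and compound 3. Replacing 4-(trifluoromethyl)phenyl with naphthalen-1-yl, which brings a second aromatic ring, gives a 1.1-fold higher number from compound 2 to compound 4 (0.06 log units; within the scatter) and so does not separate these two groups, and no measurement offered here explains any of these differences.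

Compound 3 differs from compound 2 and compound 4 in both its benzyl attachment and its nitrile, so 4-cyanophenyl attached directly to the core would show which of the two features goes with its higher number. On these data alone, it also remains open whether naphthalen-2-yl, a pyridine ring or a directly attached phenyl ring bearing an amine or a carboxylic acid would stay level with compound 2 and compound 4.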